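The compounds below may be only part of what the source reports. "The series", "measured", "known", "first", "only" and "open" are said of these compounds alone.

Measured compounds:
compound 1, `CN1CCN(CCCS(=O)(=O)c2ccc3nc(NC(=O)NC(=O)c4cc(N5CCCC5)c(C#N)cc4Cl)sc3c2)CC1`, with 2.8 in a physicochemical assay for lipophilicity; a higher number here means a more lipophilic compound, a lower number a more polar compound
compound 2, `Cc1cc(C)n(-c2ccc(Cl)c(C(=O)NC(=O)Nc3nc4ccc(S(=O)(=O)CCCN5CCN(C)CC5)cc4s3)c2)n1`, with 2.5
compound 3, `CCc1ccc(Cl)c(C(=O)NC(=O)Nc2nc3ccc(S(=O)(=O)CCCN4CCN(C)CC4)cc3s2)c1`, with 2.9

Compound 3 holds the highest of the three numbers, though its lead over compound 1 lies within the scatter; only compound 2 sits clearly lower, as the step of a number 0.40 log units higher from compound 2 to compound 3 (beyond the scatter) shows, where the 3,5-dimethyl-1H-pyrazol-1-yl group gives way to ethyl.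

Compound 4, `CN1CCN(CCCS(=O)(=O)c2ccc3nc(NC(=O)NC(=O)c4cc(N5CCCC5)ccc4Cl)sc3c2)CC1`, is reached from compound 3 through (pyrrolidin-1-yl in place of ethyl on an aromatic carbon). Among the compounds with values here, no measured pair isolates this exact exchange of pyrrolidin-1-yl for ethyl. Within the data shown here, the one measured step, a number 0.40 log units higher from compound 2 to compound 3 (beyond the scatter), concerns a different ring group and was modest. Compound 1, which also carries pyrrolidin-1-yl but adds a nitrile, lands within the scatter of compound 3, so a large move in this assay seems unlikely. A small step upward, a number 0.20 log units higher from compound 3 to compound 4 (within the scatter), is expected. For compound 4 the estimate is 3.1, expected to fall between 2.7 and 3.5.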

Compound 4, distribution coefficient: 3.1
Estimate against measurement, compound 4: no gap at the digits printed; the range from low to high includes it.
By their numbers in this assay, from the lowest: compounds 2, 1, 3 and 4 (each within the scatter of the next, the first and the last beyond it).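

In this assay, pyrrolidin-1-yl brings a ring and more heavy atoms than ethyl to this position, yet the step of a number 0.20 log units higher from compound 3 to compound 4 (within the scatter) leaves the two groups indistinguishable. Pyrrolidin-1-yl does separate from the 3,5-dimethyl-1H-pyrazol-1-yl group, with a number 0.60 log units higher from compound 2 to compound 4 (beyond the scatter) adding to the earlier ethyl result, so among these three groups the dimethylpyrazole alone stands clearly lower. Hydrogen in place of the nitrile gives a number 0.30 log units higher from compound 1 to compound 4 (within the scatter) and is the first direct reading of that change, which also cannot be told apart from no change at all.

Nothing available explains why the numbers fall this way. Going by these compounds, it also remains open whether a dimethylamino group or a carboxylic acid at this position would move the number clearly away from that of compound 4.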